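A Longer Chain and a Swap of Amine Substituents

The source may hold more compounds than are shown below. What is called first, only, known or untested is meant among the compounds shown, and "the series" means these compounds.

The four compounds differ in the amine that ends a saturated chain and in the core that carries the chain. Compound 1 `CN(C)CCCn1c(N)c(-c2nc3ccccc3[nH]2)c2nc(C#N)c(C#N)nc21` carries a dimethylamino group; in a functional assay on Raji cells (Homo sapiens) for antiproliferative activity, read by MTT assay, with a stated time of 48 h (a higher number here means a weaker inhibitor, a lower number a stronger inhibitor), compound 1 gives 1230 nM. Compound 2 `CCN(CC)CCCn1c(N)c(-c2nc3ccccc3[nH]2)c2nc(C#N)c(C#N)nc21` differs from it by diethylamino in place of dimethylamino on a saturated chain carbon, three bonds along the chain from an aromatic nitrogen, and in this assay compound 2 gives 1870 nM, so that a 1.5-fold higher number from compound 1 to compound 2 (0.18 log units; within the scatter). Compound 3 `CN(C)CCCCn1c(N)c(-c2nc3ccccc3n2C)c2nc(C#N)c(C#N)nc21` has a different core, and the difference between the two cores is not broken down here; in this assay compound 3 gives 320 nM, the lowest of the three numbers, with its steps to compound 1 and to compound 2 both beyond the scatter. Compound 4 `CCN(CC)CCCCn1c(N)c(-c2nc3ccccc3n2C)c2nc(C#N)c(C#N)nc21` is not yet measured; it differs from compound 3 by diethylamino in place of dimethylamino on a saturated chain carbon, four bonds along the chain from an aromatic nitrogen. Where the change from compound 1 to compound 2 sits three bonds along the chain from an aromatic nitrogen, this one sits four bonds along the chain from an aromatic nitrogen, so it is the same kind of change, not the same. Because a 1.5-fold higher number from compound 1 to compound 2 (0.18 log units; within the scatter) stayed within the scatter, a step of similar size is expected for compound 4, a 1.4-fold higher number from compound 3 to compound 4 (0.15 log units; within the scatter). Compound 4 is estimated at 450 nM, with a likely range from 200 nM to 1000 nM.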

Compound 4, half-maximal inhibitory concentration: 920 nM
Beside the measured number, compound 4's estimate is 2.0-fold (0.31 log units) below it; the range from low to high includes it.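

In this assay, diethylamino in place of dimethylamino on the chain of compound 3 gives a 2.9-fold higher number from compound 3 to compound 4 (0.46 log units; beyond the scatter), a step that on its own lies beyond the scatter, whereas the earlier step on the other core does not. Set side by side, however, the two steps cannot be told apart: the same change on two cores in this assay, a 1.5-fold higher number (0.18 log units; within the scatter) from compound 1 to compound 2 and a 2.9-fold higher number (0.46 log units; beyond the scatter) from compound 3 to compound 4, 1.9-fold (0.28 log units) apart, within the scatter of two such steps. Among these compounds, this shows that the change can be carried from the core of compound 1 to the core of compound 3 without a measurable difference between the two steps, but it does not show that the size of the step is the same on both, and with only two pairs, which differ in chain length as well as in core, it sets no rule for the series.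

The compounds shown leave open how a primary amine or a carboxylic acid at the end of the chain would read in this assay. They also leave open whether the same swap of amines would give a comparable step on a longer chain.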